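Replacing cyclopropyl with oxan-2-yl on an aromatic nitrogen

The source may report more compounds than this note shows. Statements on the series, on what has been measured and on what is new or still open speak of the compounds shown alone.

Compound 1 `CCCn1cc(-c2n[nH]c3cc(-c4cc(C(=O)Nc5cccc(C(F)(F)F)c5)ccc4C)ccc23)cn1`: 358 nM
Compound 2 `Cc1ccc(C(=O)Nc2cccc(C(F)(F)F)c2)cc1-c1ccc2c(-c3cnn(C(C)C)c3)n[nH]c2c1`: 452 nM
Compound 3 `Cc1ccc(C(=O)Nc2cccc(C(F)(F)F)c2)cc1-c1ccc2c(-c3cnn(C4CC4)c3)n[nH]c2c1`: 108 nM

In a functional assay on KG-1 cells (Homo sapiens) for antiproliferative activity, read by CCK-8 assay, with a stated time of 72 h (on this read-out higher numbers stand for weaker inhibition and lower numbers for stronger inhibition), compound 3 holds the lowest number of the three, at 108 nM. Within the data shown here, compound 4 `Cc1ccc(C(=O)Nc2cccc(C(F)(F)F)c2)cc1-c1ccc2c(-c3cnn(C4CCCCO4)c3)n[nH]c2c1` has oxan-2-yl in place of cyclopropyl on an aromatic nitrogen No measured compound carries oxan-2-yl, so the steps bear on this change only indirectly. Cyclopropyl stands apart in a 3.3-fold lower number from compound 1 to compound 3 (0.52 log units; beyond the scatter) and in a 4.2-fold lower number from compound 2 to compound 3 (0.62 log units; beyond the scatter), whereas a 1.3-fold higher number from compound 1 to compound 2 (0.10 log units; within the scatter) separates the two open-chain groups by little. Leaving cyclopropyl is therefore expected to raise the number by a modest amount, similar to those two steps, and the estimated step is a 3.5-fold higher number from compound 3 to compound 4 (0.55 log units; beyond the scatter). Compound 4 is estimated at 380 nM, with an expected range from 120 nM to 1200 nM.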

Compound 4, half-maximal inhibitory concentration: 121 nM
For compound 4 the middle estimate is 3.1-fold (0.50 log units) above the measured one; the range from low to high includes it.
By their numbers in this assay, from the lowest: compounds 3 and 4 (each within the scatter of the next); then compounds 1 and 2 (each within the scatter of the next).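

In this assay the six-membered oxan-2-yl ring on the aromatic nitrogen matches cyclopropyl, with a 1.1-fold higher number from compound 3 to compound 4 (0.05 log units; within the scatter) for this change, so the low number is not confined to the three-membered carbon ring. Oxan-2-yl also stands clear of both open-chain groups, with a 3.7-fold lower number from compound 2 to compound 4 (0.57 log units; beyond the scatter) and a 3.0-fold lower number from compound 1 to compound 4 (0.47 log units; beyond the scatter) in these two steps. Nothing measured here offers a reason for this result.

The compounds shown leave open whether an open-chain ether such as 2-methoxyethyl, or a ring amine such as piperidin-4-yl, would keep the number as low as these two rings do.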